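Thienyl for Pyridyl: Expecting the Next Antiproliferative Value

The compounds below may be only part of what the source reports. "The series", "measured", "known", "first", "only" and "open" are said of these compounds alone.

Compound 1 `COc1cc(C(=O)c2sc(-c3ccc(-c4ccccc4)cc3)cc2N)cc(OC)c1OC`: in a functional assay on L1210 cells (Mus musculus) for antiproliferative activity (a lower number here means a stronger inhibitor, a higher number a weaker inhibitor), compound 1 reaches only the assay limit > 10000 nM.
Compound 2 `COc1cc(C(=O)c2sc(-c3ccncc3)cc2N)cc(OC)c1OC`: in this assay compound 2 gives 1810 nM.

For the measured compounds named here, compound 2 thus holds the only actual number here. Compound 1 instead sits at the limit of > 10000 nM in this assay, at which 1 of the 2 values shown sits. Compound 3 `COc1cc(C(=O)c2sc(-c3cccs3)cc2N)cc(OC)c1OC` differs from compound 2 by thiophen-2-yl in place of pyridin-4-yl on an aromatic carbon. Going by the values given here, no measured pair shows what such a swap does, so the step of a 1.8-fold lower number from compound 2 to compound 3 (0.26 log units; within the scatter) is expected to be small, barely beyond the scatter if at all, leaning toward a somewhat stronger inhibitor. Compound 3 is therefore estimated at 1000 nM, within 200 nM to 6000 nM.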

Compound 3, half-maximal inhibitory concentration: 9.8 nM
Compound 3: the middle estimate sits 100-fold (2.01 log units) above what was measured; the whole stated range lies above it.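

In this assay, thiophen-2-yl in place of pyridin-4-yl gives a 180-fold lower number from compound 2 to compound 3 (2.27 log units; beyond the scatter), so a single change of aromatic ring at this position, next to the ring sulfur, can shift the value far beyond the scatter. The earlier compounds shown here could not show this sensitivity, since they offered no step that could be read. Nothing measured here accounts for the size of this step. From the compounds shown here alone, it remains open whether phenyl, furan-2-yl or thiophen-3-yl would give a value close to that of compound 3. A single pair also cannot say how a small methyl group would fare at this position.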